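A Bromo Analogue in a Flat Series

The source may hold more compounds than are shown below. What is called first, only, known or untested is meant among the compounds shown, and "the series" means these compounds.

Compound 3 `C=CCOc1c(C)c(C)c2c(c1C)CCC(C)(COc1ccc(/C=C3\SC(=O)NC3=O)cc1C)O2` belongs to a set of three close relatives. In a functional assay on MCF7 cells (Homo sapiens), tested at 7.5 uM (a higher number here means a weaker effect of the compound at the concentration tested, a lower number a stronger effect), compound 3 gives 8%. Compound 1 `C=CCOc1c(C)c(C)c2c(c1C)CCC(C)(COc1ccc(/C=C3\SC(=O)NC3=O)cc1)O2` gives 2% in this assay, and compound 2 `C=CCOc1c(C)c(C)c2c(c1C)CCC(C)(COc1ccc(/C=C3\SC(=O)NC3=O)cc1OC)O2` gives 1%. Compound 3 thus holds the highest of the three numbers, yet the gaps are small: a number 6 percentage points higher from compound 1 to compound 3 (within the scatter) and a number 7 percentage points higher from compound 2 to compound 3 (within the scatter). Compound 4 `C=CCOc1c(C)c(C)c2c(c1C)CCC(C)(COc1ccc(/C=C3\SC(=O)NC3=O)cc1Br)O2` has not yet been measured. It differs from compound 3 in one place: bromo in place of methyl on an aromatic carbon. The measured steps that bear on this position, including a number 1 percentage points lower from compound 1 to compound 2 (within the scatter), all concern the same aromatic carbon, and none left the scatter, so no step beyond the scatter is expected here: a number 2 percentage points lower from compound 3 to compound 4 (within the scatter). Compound 4 is therefore estimated at 6%, with a range from 0% to 18%.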

Compound 4, a percentage reported as activity, at one concentration (the size of the read-out at that concentration, not a potency): 105%
Compound 4: middle estimate off by 99 percentage points, on the low side, and the stated range ends below it.
By their numbers in this assay, from the lowest: compounds 2, 1 and 3 (each within the scatter of the next); then compound 4.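

In this assay, this aromatic carbon proves far from indifferent: hydrogen, methoxy and methyl give numbers within the scatter of one another, but bromo stands apart, with a number 97 percentage points higher from compound 3 to compound 4 (beyond the scatter), a number 104 percentage points higher from compound 2 to compound 4 (beyond the scatter) and a number 103 percentage points higher from compound 1 to compound 4 (beyond the scatter). Among these four compounds, then, the effect at the concentration tested is largely lost only with bromo. Nothing available here explains this sharp break. Going by these compounds, whether chloro or a nitrile on the same carbon would behave like bromo, or like the three smaller-step relatives, remains open.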